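Swapping a fluorophenyl for benzyl on a weak core

The compounds below may be only part of what the source reports. "The series", "measured", "known", "first", "only" and "open" are said of these compounds alone.

Compound 1 `CCCCCCc1cc2cn(Cc3cn(-c4ccccc4F)nn3)c(=O)nc2o1` was examined in a functional assay on HepG2 cells (Homo sapiens) for antiproliferative activity, read by MTT assay, with a stated time of 72 h; a lower number here means a stronger inhibitor, a higher number a weaker inhibitor. In this assay compound 1 gives only a limit, > 100000 nM, so its true potency is not pinned down, as the limit of > 100000 nM in this assay, at which 1 of the 3 values shown sits, shows. Compound 2 `O=c1nc2oc(CCCCl)cc2cn1Cc1cn(-c2ccccc2F)nn1` carries a shorter chain ending in chlorine and in this assay gives 79800 nM; the step of an at least 1.2-fold lower number from compound 1 to compound 2 (0.09 log units; that floor lies within the scatter) is an at-least figure whose floor lies within the usual scatter. Compound 3 `O=c1nc2oc(CCCCl)c(C#CCCCCl)c2cn1Cc1cn(Cc2ccccc2)nn1` differs from both in more than one place and in this assay gives 25500 nM; its number can only be set beside theirs, not traced to one change.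

Compound 4 `CCCCCCc1cc2cn(Cc3cn(Cc4ccccc4)nn3)c(=O)nc2o1` differs from compound 1 by benzyl in place of 2-fluorophenyl on an aromatic nitrogen. Going by the values given here, no measured step matches this change; the only measured step, from compound 1 to compound 2, touches a different part of the molecule and was itself small. Compound 4 is therefore expected to stay near the limit, with an estimated value of 90000 nM and a range from 30000 nM to 300000 nM. The expected step of an at least 1.1-fold lower number from compound 1 to compound 4 (0.04 log units; that floor lies within the scatter) is judged to lie within the scatter.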

Compound 4, half-maximal inhibitory concentration: 68700 nM
For compound 4 the middle estimate is 1.3-fold (0.12 log units) above the measured one; the range from low to high includes it.
By their numbers in this assay, from the lowest: compound 3; then compounds 4 and 2 (each within the scatter of the next). At a limit, above all of these: compound 1.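

Benzyl in place of 2-fluorophenyl on this aromatic nitrogen gives, in this assay, an at least 1.4-fold lower number from compound 1 to compound 4 (0.16 log units; that floor lies within the scatter). On these data alone, compound 1 stands at a limit rather than a number, so the true size of this step stays unknown and could be larger than its floor: the limit of > 100000 nM in this assay, at which 1 of the 4 values shown sits. Compound 4 has a measured value where compound 1 has only that limit, which gives this position one firm number for comparing other groups on the same core.

As far as these compounds go, it remains open whether the loss of the fluorine or the gain of the extra carbon in benzyl matters more, and plain phenyl on this nitrogen would separate the two. Also open, from the compounds shown here alone, is how a benzyl ring carrying an amine or a carboxylic acid would read in this assay.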